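Swapping Fluoro for Bromo on a Weakly Inhibiting Series

The compounds below may be only part of what the source reports. "The series", "measured", "known", "first", "only" and "open" are said of these compounds alone.

Of the compounds shown here, three built on one shared core have been measured in a functional assay on BGC-823 cells (Homo sapiens) for inhibition, read by CCK-8 assay, with a stated time of 48 h; on this read-out lower numbers stand for stronger inhibition and higher numbers for weaker inhibition. Compound 1 `Fc1ccc(C2=NN(C3=NC(c4ccccc4)CS3)C(c3cccc4ccccc34)C2)cc1` gives 22700 nM. Compound 2 `Fc1ccc(C2=NN(C3=NC(c4ccccc4)CS3)C(c3ccc4ccccc4c3)C2)cc1` gives 17300 nM, and compound 3 `O=C1CSC(N2N=C(c3ccc(F)cc3)CC2c2cccc3ccccc23)=N1` gives 19300 nM. Compound 1 has the highest of the three numbers, yet the step of a 1.3-fold lower number from compound 1 to compound 2 (0.12 log units; within the scatter) and the step of a 1.2-fold lower number from compound 1 to compound 3 (0.07 log units; within the scatter) are both within the scatter, so the three compounds cannot be told apart in this assay.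

Compound 4 `Brc1ccc(C2=NN(C3=NC(c4ccccc4)CS3)C(c3cccc4ccccc34)C2)cc1` has not yet been measured. It differs from compound 1 by bromo in place of fluoro on an aromatic carbon. Neither measured step touches this position: one exchanged naphthalen-2-yl for naphthalen-1-yl, the other replaced a group on the ring amine nitrogen, and both stayed within the scatter. Going by the values given here, no measured step therefore bears directly on the halogen change, and no direction can be read from the data.

The expectation for compound 4 is a step of a 1.2-fold lower number from compound 1 to compound 4 (0.08 log units; within the scatter), that is, no change beyond the scatter. The estimated value for compound 4 in this assay is 19000 nM, with a range from 7000 nM to 55000 nM.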

Compound 4, half-maximal inhibitory concentration: 17400 nM
The estimate for compound 4 lay 1.1-fold (0.04 log units) above the measured number; measured number inside the range.
By their numbers in this assay, from the lowest: compounds 2, 4, 3 and 1 (each within the scatter of the next).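

In this assay, putting bromo in place of fluoro gives a 1.3-fold lower number from compound 1 to compound 4 (0.12 log units; within the scatter), the only measured change among these compounds at this aromatic carbon. The earlier steps shown here concerned the naphthalene attachment and the group on the ring amine nitrogen, whereas this pair shows that going from 4-fluorophenyl to 4-bromophenyl also leaves the number within the scatter. Nothing measured here offers an explanation for this result.

Going by these compounds, it remains open whether a group other than a halogen at this position, such as an amine, a methoxy group or a carboxylic acid, would shift the number beyond the scatter. On these data alone, it is also open whether bromo would read the same way when combined with the other structures, those of compound 2 and compound 3.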